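Swapping an Alkyl Amine for an Aryl Amide

The source may hold more compounds than are shown below. What is called first, only, known or untested is meant among the compounds shown, and "the series" means these compounds.

Measured so far:
- compound 1, `CCCNc1nc(-c2ccccc2)nc2c1nnn2Cc1ccccc1F`: 3200000 nM
- compound 2, `CCCNc1nc(-c2ccccc2)nc2c1nnn2Cc1ccccc1`: 37000000 nM
- compound 3, `CCCCNc1nc(-c2ccccc2)nc2c1nnn2Cc1ccccc1`: 11000000 nM

All three compounds share one core and were tested in an assay on isolated protein for binding affinity to adenosine receptor A1 (Bos taurus); a higher number here means a weaker inhibitor, a lower number a stronger inhibitor. Compound 1 gives the lowest number of the three, so it is the strongest binder here; compound 3 comes nearest, and compound 2 lies furthest away. The step of a 12-fold higher number from compound 1 to compound 2 (1.06 log units; beyond the scatter) shows that removing the fluoro costs a great deal, while the step of a 3.4-fold lower number from compound 2 to compound 3 (0.53 log units; beyond the scatter) shows that lengthening the chain on the ring nitrogen gains a little.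

The unmeasured compound 4, `COc1ccc(C(=O)Nc2nc(-c3ccccc3)nc3c2nnn3Cc2ccccc2F)cc1`, differs from compound 1 in one place: (4-methoxyphenyl)carbonyl in place of propyl on a nitrogen on an aromatic ring. Neither measured step covers this exact change. The nearest analogy is the step from compound 2 to compound 3, which also alters the group on that same nitrogen, but only by one carbon; compound 4 replaces the whole propyl with a larger, ring-bearing acyl group, and the fluoro of compound 1 is kept. The direction is therefore uncertain, and the range must be wide.

On balance, compound 4 is expected to give about 1500000 nM in this assay, somewhere between 200000 nM and 10000000 nM, which would mean an estimated step of a 2.1-fold lower number from compound 1 to compound 4 (0.33 log units; beyond the scatter).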

Compound 4, inhibition constant: 21900000 nM
Compound 4: middle estimate off by 15-fold (1.16 log units), on the low side; measured number outside the range, above it.
By their numbers in this assay, from the lowest: compound 1; then compounds 3, 4 and 2 (each within the scatter of the next, the first and the last beyond it).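

In this assay, putting (4-methoxyphenyl)carbonyl in place of propyl on the nitrogen gives a 6.8-fold higher number from compound 1 to compound 4 (0.84 log units; beyond the scatter) with the fluoro of compound 1 kept, so this larger, ring-bearing group weakens binding. Among the compounds shown here, the earlier compounds carried only alkyl chains on this nitrogen, and their single change there, a 3.4-fold lower number from compound 2 to compound 3 (0.53 log units; beyond the scatter), moved towards stronger binding; the new result shows that the same position can also move the number the opposite way when propylamino becomes an amide. No measurement at hand tells why this exchange costs binding.

As far as these compounds go, it remains open whether the loss belongs to the carbonyl, to the aromatic ring or to the methoxy, since all three arrive together in this one change. A benzyl group on that nitrogen would keep the ring without the carbonyl, an acetyl group would keep the carbonyl without the ring, and a plain benzoyl group would keep both without the methoxy, so these three could pull the parts of the change apart.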